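Solubility notes: from compound 2 to compound 3

This account rests on a few compounds, and the source may have more. Where it says the series, first, only, none or still open, it means among the compounds named here.

Measured compounds:
compound 1 `COc1ccc(F)cc1CNCCCNc1ccnc2cc(CCC(C)C)ccc12`: 4200 nM
compound 2 `COc1ccc(F)cc1CNCCCNc1ccnc2cc(-c3ccc(C(C)(C)C)cc3)ccc12`: 32000 nM

In a physicochemical assay for solubility, with a stated time of 18 h, at pH 7.4 (on this read-out higher numbers stand for higher solubility and lower numbers for lower solubility), compound 1 gives 4200 nM and compound 2 gives 32000 nM. Compound 2 stands highest of the two numbers, separated from compound 1 by a single measured step, a 7.6-fold higher number from compound 1 to compound 2 (0.88 log units; beyond the scatter). Compound 3 `COc1ccc(F)cc1CNCCCNc1ccnc2cc(-c3cccc4ccccc34)ccc12` differs from compound 2 in one place: naphthalen-1-yl in place of 4-(tert-butyl)phenyl on an aromatic carbon. Among the compounds with values here, the one measured step exchanged a branched chain for an aromatic ring; no measured pair exchanges one aromatic group for another, so that step bears on the present change only loosely. With the two groups matching in what is counted, a step no larger than the scatter, possibly toward a lower number, is the working expectation. For compound 3 the estimate in this assay is 18000 nM, within a range of 6000 nM to 50000 nM. The expected step is a 1.8-fold lower number from compound 2 to compound 3 (0.25 log units; within the scatter).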

Compound 3, solubility: 32000 nM
For compound 3 the middle estimate is 1.8-fold (0.25 log units) below the measured one; low and high end bracket the measured number.
By their numbers in this assay, from the lowest: compound 1; then compounds 2 and 3 (each within the scatter of the next).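

In this assay, naphthalen-1-yl in place of 4-(tert-butyl)phenyl gives no change at the digits printed from compound 2 to compound 3 (within the scatter), so on this aromatic carbon, two fused aromatic rings read the same as one ring carrying tert-butyl, at an equal count of heavy atoms. Naphthalen-1-yl in place of isopentyl gives a 7.6-fold higher number from compound 1 to compound 3 (0.88 log units; beyond the scatter), so among these three compounds, both aromatic groups stand apart from the branched chain by the same margin, and neither goes against this. No supporting measurement offers a reason for either step.

Open, on these data alone, is whether plain phenyl, or a saturated ring such as cyclohexyl, would read with the aromatic pair or with isopentyl. Also open, as far as these compounds go, is how an aromatic ring carrying an amine or a carboxylic acid would read at this place.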